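Solubility across aryl ether and benzyl variants of the shared core

The source may hold more compounds than are shown below. What is called first, only, known or untested is meant among the compounds shown, and "the series" means these compounds.

Measured compounds:
Compound 1, `COc1cccc(CNCCCNc2ccnc3cc(Oc4ccccc4)ccc23)c1O`, 14500 nM
Compound 2, `COc1cccc(CNCCCNc2ccnc3cc(-c4ccc(F)cc4)ccc23)c1O`, 32000 nM
Compound 3, `COc1cccc(CNCCCNc2ccnc3cc(Cc4cc(C)cc(C)c4)ccc23)c1O`, 4200 nM

All three were run in a physicochemical assay for solubility, with a stated time of 18 h, at pH 7.4; a higher number here means a more soluble compound, a lower number a less soluble compound. Compound 3 gives the lowest number of the three: the step of a 3.5-fold lower number from compound 1 to compound 3 (0.54 log units; beyond the scatter) and the step of a 7.6-fold lower number from compound 2 to compound 3 (0.88 log units; beyond the scatter) both lie beyond the scatter, so compound 3 is the least soluble of the measured set on these numbers. Compound 2 gives the highest number, with a 2.2-fold higher number from compound 1 to compound 2 (0.34 log units; beyond the scatter) also beyond the scatter.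

The unmeasured compound 4, `COc1ccc(Oc2ccc3c(NCCCNCc4cccc(OC)c4O)ccnc3c2)cc1`, differs from compound 3 in one place: 4-methoxyphenoxy in place of 3,5-dimethylbenzyl on an aromatic carbon. Among the compounds with values here, the step that bears most directly on this change is a 3.5-fold lower number from compound 1 to compound 3 (0.54 log units; beyond the scatter), since compound 1 carries a phenoxy at the same position and compound 4 carries a 4-methoxyphenoxy there; the methoxy is the only difference between the group on compound 1 and the group on compound 4. Within the data shown here, no measured pair isolates that methoxy, so its own contribution is unknown. The expectation is therefore that compound 4 returns toward the region of compound 1, with an estimated step of a 2.9-fold higher number from compound 3 to compound 4 (0.46 log units; beyond the scatter) in this assay. For compound 4 the estimate is 12000 nM, with a range from 4500 nM to 32000 nM.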

Compound 4, solubility: 14500 nM
Compound 4: the middle estimate sits 1.2-fold (0.08 log units) below what was measured; the measured number falls inside the stated range.
By their numbers in this assay, from the lowest: compound 3; then compounds 1 and 4 (each within the scatter of the next); then compound 2.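

In this assay, within the data shown here, methoxy in place of hydrogen on an aromatic carbon gives no change at the digits printed from compound 1 to compound 4 (within the scatter), the first measured pair to isolate this group on the phenoxy ring, and the two aryl ethers cannot be told apart in this assay. Replacing 3,5-dimethylbenzyl with 4-methoxyphenoxy, which has the same heavy-atom count, gives a 3.5-fold higher number from compound 3 to compound 4 (0.54 log units; beyond the scatter), while replacing 4-fluorophenyl with 4-methoxyphenoxy gives a 2.2-fold lower number from compound 2 to compound 4 (0.34 log units; beyond the scatter), so a second aryl ether also lies beyond the scatter from both non-ether groups. Nothing offered here accounts for any of these steps.

The effect of the connection to the shared core remains unresolved, since the phenoxy, 4-fluorophenyl and 3,5-dimethylbenzyl groups differ in both the link and the substituents on the ring, and an unsubstituted benzyl or phenyl group would help separate the two. On these data alone, it is also open whether the absence of a measurable methoxy step extends to other substituents on the phenoxy ring, such as a dimethylamino group or a carboxylic acid at the same ring carbon.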